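A few compounds are considered here, and "the series" means these few. Any claim that something is new, unique, unknown or untested is made for them only; others in the source may bear on it.

Among the measured compounds shown here, in a functional assay on HeLa cells (Homo sapiens) for cytotoxicity, read by MTT assay, with a stated time of 2 days (on this read-out higher numbers stand for weaker inhibition and lower numbers for stronger inhibition), compound 1 (`CCN(CC)c1ccc2nc(-c3ccccc3OC(F)(F)F)[nH]c(=O)c2c1`) gives 40 nM and is the only compound here with an exact reading. Compound 2 (`Cc1ccc2nc(-c3cccc(C(F)(F)F)c3)[nH]c(=O)c2c1`) has > 50000 nM as its entry, which is a limit and not a number. For the measured compounds named here, compound 2 thus stands at the limit of > 50000 nM in this assay, at which 1 of the 2 values shown sits, and no measured step connects it to compound 1.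

Compound 3 (`Cc1ccc2nc(-c3cccc(F)c3)[nH]c(=O)c2c1`) has not yet been measured. Compared with compound 2, it carries fluoro in place of trifluoromethyl on an aromatic carbon, meta to a large group (fluoro in place of trifluoromethyl on an aromatic carbon). With compound 2 at > 50000 nM as a limit, only a small step is expected in this assay, towards stronger inhibition if it shows at all, and a limit may well be reported again. The estimated step (an at least 1.2-fold lower number from compound 2 to compound 3 (0.09 log units; that floor lies within the scatter)) is expected to stay modest. For compound 3 the expected value is 40000 nM with an estimated range from 8000 nM to 100000 nM as the likely span.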

Compound 3, half-maximal inhibitory concentration: > 50000 nM
Compound 3 was reported as a limit; the forecaster's own chance of this, stated with the estimate: 60%; middle value at least 1.2-fold (0.09 log units) from the limit.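

In this assay no step can be read from compound 2 to compound 3, because both entries are limits and not numbers: the limit of > 50000 nM in this assay, at which 2 of the 3 values shown sit. The compounds shown leave open whether fluoro in place of trifluoromethyl changes the reading at all, and which structural difference separates these two compounds from compound 1, which gives 40 nM.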